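Acetyl to dimethylamino swap: cytotoxicity notes

This account rests on a few compounds, and the source may have more. Where it says the series, first, only, none or still open, it means among the compounds named here.

Measured so far:
compound 1 `COc1cc(C)cc(-c2c(-c3ccnc(-c4ccc(C(C)=O)cc4)c3)cnn2CC#N)c1` — 89%
compound 2 `Cc1cc(O)cc(-c2nn(CC#N)cc2-c2ccnc(-c3ccc(N(C)C)cc3)c2)c1` — 91%

In a functional assay on U-251 cells (Homo sapiens) for cytotoxicity, read by sulforhodamine B assay, with a stated time of 48 h, tested at 100 nM (on this read-out higher numbers stand for a weaker effect at the one concentration tested and lower numbers for a stronger effect), compound 1 gives 89%, the lower of the two numbers, while compound 2 gives 91%; the gap lies within the scatter, so neither stands apart. Among the compounds with values here, no step between measured compounds is defined. Compound 3 `COc1cc(C)cc(-c2c(-c3ccnc(-c4ccc(N(C)C)cc4)c3)cnn2CC#N)c1` differs from compound 1 by dimethylamino in place of acetyl on an aromatic carbon. The dimethylamino group already sits in compound 2, whose value sits within the scatter of compound 1, so the expected step is a number 1 percentage points higher from compound 1 to compound 3 (within the scatter), nothing beyond the scatter. Compound 3 is estimated at 90%, range 78% to 100%.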

Compound 3, a percentage reported as activity, at one concentration (the size of the read-out at that concentration, not a potency): 6%
Beside the measured number, compound 3's estimate is 84 percentage points above it; measured number outside the range, below it.
By their numbers in this assay, from the lowest: compound 3; then compounds 1 and 2 (each within the scatter of the next).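

In this assay, the change from 4-acetylphenyl to 4-(dimethylamino)phenyl gives a number 83 percentage points lower from compound 1 to compound 3 (beyond the scatter), so the read-out on the core of compound 1 depends strongly on the group at this aromatic carbon, para to a large group. The two groups match in heavy-atom count and hydrogen-bond acceptor count and carry no net charge, so these counts do not separate them. No measurement bearing on the cause of this step is available.

Going by these compounds, whether a primary amine, a methoxy group or a pyrrolidine at this carbon would give a similarly strong effect remains open. So does how far the step depends on the rest of the core of compound 1.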